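A larger ether in place of methoxy on compound 3

A few compounds are considered here, and "the series" means these few. Any claim that something is new, unique, unknown or untested is made for them only; others in the source may bear on it.

Three compounds share one core and differ only in the aromatic ring attached to it. In an assay on T-REx-293 cells for inhibition of potassium channel subfamily T member 1 (Homo sapiens), read by patch clamp (on this read-out higher numbers stand for weaker inhibition and lower numbers for stronger inhibition), compound 1 `Cc1cccc(-c2noc([C@H](C)NC(=O)c3cc(C(F)(F)F)nn3C)n2)n1` reaches only a limit, > 30000 nM, and no number. Compound 2 `Cc1cc(-c2noc([C@H](C)NC(=O)c3cc(C(F)(F)F)nn3C)n2)ncn1` gives 1410 nM in this assay. Compound 3 `COc1cc(-c2noc([C@H](C)NC(=O)c3cc(C(F)(F)F)nn3C)n2)ccn1` gives 27 nM in this assay, the lowest of the two numbers; its nearest neighbour is compound 2, and the step of a 52-fold lower number from compound 2 to compound 3 (1.72 log units; beyond the scatter) was large. The steps of an at least 1100-fold lower number from compound 1 to compound 3 (3.04 log units; beyond the scatter) and an at least 21-fold lower number from compound 1 to compound 2 (1.32 log units; beyond the scatter) were large as well, though both rest on the limit (the limit of > 30000 nM in this assay, at which 1 of the 3 values shown sits).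

Compound 4 `COC(C)(C)c1cc(-c2noc([C@H](C)NC(=O)c3cc(C(F)(F)F)nn3C)n2)ccn1` keeps the ring of compound 3 and alters only the group on it: 1-methoxy-1-methylethyl in place of methoxy on an aromatic carbon. Within the data shown here, none of the measured steps is of this kind; each exchanges the whole ring, whereas here the ring stays and only the ether grows. The measured steps show that the choice of ring matters greatly, but they give no guide to how a larger ether on the same ring behaves. The change from compound 3 to compound 4 is expected to be modest, most likely a somewhat higher number, a 3.0-fold higher number from compound 3 to compound 4 (0.47 log units; beyond the scatter). Compound 4 is therefore estimated at 80 nM, between 20 nM and 300 nM.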

Compound 4, half-maximal inhibitory concentration: 6280 nM
For compound 4 the middle estimate is 79-fold (1.89 log units) below the measured one; measured number outside the range, above it.
By their numbers in this assay, from the lowest: compound 3; then compound 2; then compound 4. At a limit, above all of these: compound 1.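

Among these compounds, until now only whole rings had been exchanged, so the earlier compounds said nothing about the group on the ring. With the ring of compound 3 kept and only the ether enlarged, this assay shows a 230-fold higher number from compound 3 to compound 4 (2.37 log units; beyond the scatter), a larger change than the ring exchange a 52-fold lower number from compound 2 to compound 3 (1.72 log units; beyond the scatter), so the substituent on this aromatic carbon, next to the ring nitrogen, can matter at least as much as the choice of ring. Methoxy and 1-methoxy-1-methylethyl match in their counts of hydrogen-bond donors and acceptors and in net charge and differ in heavy atoms and carbon count, yet nothing measured here explains why this weakens inhibition so strongly.

Among the compounds shown here, with only two groups at this position, it stays open whether the rise in the number follows the count of heavy atoms, the branching at the carbon attached to the ring, or the placing of the ether oxygen. An ethoxy group, a longer straight ether chain, a tert-butyl group without oxygen or a small amine such as dimethylamino on the same carbon would help separate these possibilities.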